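The compounds below may be only part of what the source reports. "The series", "measured", "known", "first", "only" and "open" are said of these compounds alone.

The series shares one core and is followed in a functional assay on DU-145 cells (Homo sapiens) for inhibition, read by sulforhodamine B assay, with a stated time of 72 h; on this read-out higher numbers stand for weaker inhibition of growth and lower numbers for stronger inhibition of growth. Compound 1, `CC(C)(C)OC(=O)NCCCCCNC1=Nc2ccccc2C(CC(=O)NCc2ccccc2)N1c1ccccc1`, gives in this assay 4260 nM. Compound 2, `COC(=O)CC1c2ccccc2N=C(NCCCCCNC(=O)OC(C)(C)C)N1c1ccc(-c2ccccc2)cc1`, gives in this assay 3830 nM. Compound 2 has the lowest of the two numbers, and its nearest neighbour is compound 1, whose number lies within the scatter of it; as the two compounds differ in more than one place, their values show only that both sit in the same region.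

The step under consideration leads from compound 2 to compound 3, `CC(C)(C)OC(=O)NCCCCCNC1=Nc2ccccc2C(CC(=O)NCc2ccccc2)N1c1ccc(-c2ccccc2)cc1`. The change is benzylamino in place of methoxy on a carbonyl carbon, the carbonyl sitting on a saturated chain carbon. Going by the values given here, no measured pair in the set isolates this change, so the expectation rests on the two numbers alone, with compound 1 at 4260 nM already carrying the benzylcarbamoyl group. From compound 2 to compound 3 the expected step is a 1.1-fold lower number from compound 2 to compound 3 (0.04 log units; within the scatter), which stays within the scatter. Compound 3 is therefore estimated at 3500 nM, with a range from 1400 nM to 9000 nM.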

Compound 3, concentration for 50% growth inhibition: 1640 nM
Compound 3: the middle estimate sits 2.1-fold (0.33 log units) above what was measured, within the range that was stated.
By their numbers in this assay, from the lowest: compound 3; then compounds 2 and 1 (each within the scatter of the next).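

In this assay, the exchange of methoxy for benzylamino on a carbonyl carbon, with the carbonyl sitting on a saturated chain carbon, gives a 2.3-fold lower number from compound 2 to compound 3 (0.37 log units; beyond the scatter), so methoxycarbonyl and benzylcarbamoyl can be told apart at this position when the phenyl group is present. The second single change, phenyl in place of hydrogen on an aromatic carbon, gives a 2.6-fold lower number from compound 1 to compound 3 (0.41 log units; beyond the scatter) with the benzylcarbamoyl group held in place, showing that this site also moves the growth-inhibition read-out by a modest step beyond the scatter. No supporting measurement is available to explain either step.

Each change is seen in only one setting, so the compounds shown leave open whether the benzylamino exchange would give a similar step without the added phenyl group, and whether the phenyl group would do so with methoxycarbonyl in place of benzylcarbamoyl. They also leave open how a carboxylic acid, or a methylamino group on the same carbonyl carbon, would compare with methoxy and benzylamino at this position.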